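The source may report more compounds than this note shows. Statements on the series, on what has been measured and on what is new or still open speak of the compounds shown alone.

Measured compounds:
compound 1 `O=C1N=C(N2N=C(c3ccccc3)CC2c2ccccc2O)S/C1=C1/C(=O)Nc2ccc(Br)cc21`: 630 nM
compound 2 `COc1ccc(C2CC(c3ccccc3)=NN2C2=NC(=O)/C(=C3\C(=O)Nc4ccc(Br)cc43)S2)cc1`: 360 nM
compound 3 `COc1ccc(C2=NN(C3=NC(=O)/C(=C4\C(=O)Nc5ccc(Br)cc54)S3)C(c3ccc(OC)cc3)C2)cc1`: 380 nM

All three were tested in a functional assay on cells (Cancer cell lines, Homo sapiens) for cytotoxicity, read by sulforhodamine B assay, with a stated time of 48 h; a higher number here means a weaker inhibitor of growth, a lower number a stronger inhibitor of growth. Compound 2 gives the lowest of the three numbers, but its gap to compound 3 and its gap to compound 1 both lie within the scatter, so the three stand together. Compound 4 `CN(C)c1ccc(C2CC(c3ccccc3)=NN2C2=NC(=O)/C(=C3\C(=O)Nc4ccc(Br)cc43)S2)cc1` has not yet been measured in this assay. It differs from compound 2 in one place: dimethylamino in place of methoxy on an aromatic carbon. Going by the values given here, two measured steps touch the same part of the molecule. The step of a 1.8-fold lower number from compound 1 to compound 2 (0.24 log units; within the scatter) exchanged the whole group on the saturated ring carbon, and the step of a 1.1-fold higher number from compound 2 to compound 3 (0.02 log units; within the scatter) added a methoxy on an aromatic carbon; neither moved the number beyond the scatter. On that basis the exchange of methoxy for dimethylamino in compound 4 is expected to give a step of about no change at the digits printed from compound 2 to compound 4 (within the scatter) in this assay, that is, none beyond the scatter. Compound 4 is therefore estimated at 360 nM, in a range from 180 nM to 720 nM.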

Compound 4, concentration for total growth inhibition: 450 nM
Estimate against measurement, compound 4: 1.3-fold (0.10 log units) below; the measured number falls inside the stated range.
By their numbers in this assay, from the lowest: compounds 2, 3, 4 and 1 (each within the scatter of the next).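

In this assay, the change on the aromatic carbon para to a large group gives a 1.3-fold higher number from compound 2 to compound 4 (0.10 log units; within the scatter), so dimethylamino and methoxy cannot be told apart there, and this place now holds a nitrogen-linked group as well as an oxygen-linked one. Exchanging the whole group on the saturated ring carbon, with 4-(dimethylamino)phenyl in place of 2-hydroxyphenyl, gives a 1.4-fold lower number from compound 1 to compound 4 (0.15 log units; within the scatter), so all three aryl groups carried at that carbon by compound 1, compound 2 and compound 4 stand together. No measurement offered here accounts for these numbers.

The compounds shown leave open whether a carboxylic acid or a primary amine at this place on the ring would give a step beyond the scatter. On these data alone, it also remains open how a longer alkyl chain, in place of the aryl group on the saturated ring carbon, would read.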